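Amine substituent change on the shared core: compound 3 to compound 4

A few compounds are considered here, and "the series" means these few. Any claim that something is new, unique, unknown or untested is made for them only; others in the source may bear on it.

Measured compounds:
compound 1 `Cc1ccc(-c2cnc(N)nc2-c2ccccc2)cc1`: 51%
compound 2 `Nc1ncc(-c2ccc(Cl)cc2)c(-c2ccccc2)n1`: 41%
compound 3 `O=C(Nc1ncc(-c2cccc(Cl)c2)c(-c2ccccc2)n1)C1CCCC1`: 47%

In an assay on CHO cells for displacement of a labelled ligand from adenosine receptor A1 (Homo sapiens), read by scintillation counting, with a stated time of 1 h, tested at 1 uM (on this read-out higher numbers stand for more inhibition at the one concentration tested (going by the name of the read-out) and lower numbers for less inhibition), compound 3 gives 47%, which is the second highest of the three numbers; its nearest neighbour is compound 1 and its furthest is compound 2, and both gaps lie within the scatter, so no order among the three can be stated.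

Within the data shown here, the only step measured within one change is a number 10 percentage points lower from compound 1 to compound 2 (within the scatter). That step alters a substituent on an aromatic carbon and leaves the amine untouched, so it does not bear on the change now at hand.

Compound 4 `C#CCNc1ncc(-c2cccc(Cl)c2)c(-c2ccccc2)n1` differs from compound 3 by propargyl in place of cyclopentylcarbonyl on a nitrogen on an aromatic ring; cut one bond further out, the same difference reads (cyclopentylcarbonyl)amino to propargylamino. The group that leaves carries a five-membered non-aromatic ring and a hydrogen-bond acceptor; the group that enters has no ring and a triple bond outside aromatic rings. Compounds 1 and 2 carry an unsubstituted amine on the same nitrogen, and their values sit within the scatter of compound 3, so the data give no sign that this nitrogen substituent moves the read-out much. The expected step is a number 2 percentage points lower from compound 3 to compound 4 (within the scatter), not beyond the scatter. For compound 4 the estimate in this assay is 45% with a range of 25% to 65%.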

Compound 4, a percentage reported as inhibition, at one concentration (the size of the read-out at that concentration, not a potency): 76%
The estimate for compound 4 lay 31 percentage points below the measured number; the measured number lies above the stated range.
By their numbers in this assay, from the lowest: compounds 2, 3 and 1 (each within the scatter of the next); then compound 4.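

In this assay, among these compounds, propargyl in place of cyclopentylcarbonyl on a nitrogen on an aromatic ring gives a number 29 percentage points higher from compound 3 to compound 4 (beyond the scatter), so a change at this nitrogen can move the read-out beyond the scatter, which the only earlier step, a change on an aromatic carbon, did not show. This single step changes several things at once: the five-membered non-aromatic ring and the carbonyl leave, and the triple bond enters, so it cannot assign the rise to any one of them. No measurement at hand explains the rise.

Open, going by these compounds, is whether the rise follows the triple bond or the loss of the cyclopentylcarbonyl group. A propyl or cyclopentyl group on the same nitrogen of the shared core would separate these two readings.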